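The source may report more compounds than this note shows. Statements on the series, on what has been measured and on what is new or still open speak of the compounds shown alone.

Within the data shown here, in a functional assay on MT4 cells (Homo sapiens) for cytotoxicity (a higher number here means a weaker inhibitor, a lower number a stronger inhibitor), compound 1 `N#Cc1c(N)cccc1Sc1ccccc1` gives 168000 nM, the higher of the two numbers measured so far. Among the measured compounds shown here, the only other measured compound, compound 2 `N#Cc1c(N)cccc1Sc1ccccc1Br`, gives 41000 nM. Compound 3 `N#Cc1cccc(Sc2cccc(N)c2C#N)c1` has not yet been measured. It differs from compound 1 by a single change: cyano in place of hydrogen on an aromatic carbon.

For the measured compounds named here, only one measured step bears on this change: a 4.1-fold lower number from compound 1 to compound 2 (0.61 log units; beyond the scatter). There, bromo replaced hydrogen on an aromatic carbon, and the step was modest but beyond the scatter. It is a thin guide, as cyano is a different group from bromo and one step cannot establish a trend. Going by a 4.1-fold lower number from compound 1 to compound 2 (0.61 log units; beyond the scatter), a smaller move in the same direction is expected, and it may well stay within the scatter. The estimate amounts to an expected step of a 1.7-fold lower number from compound 1 to compound 3 (0.23 log units; within the scatter). In this assay, compound 3 is expected to give 100000 nM, with an estimated range of 30000 nM to 250000 nM.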

Compound 3, half-maximal inhibitory concentration: 80000 nM
For compound 3 the middle estimate is 1.3-fold (0.10 log units) above the measured one; the range from low to high includes it.
By their numbers in this assay, from the lowest: compounds 2 and 3 (each within the scatter of the next); then compound 1.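

In this assay the step of a 2.1-fold lower number from compound 1 to compound 3 (0.32 log units; beyond the scatter) shows that cyano in place of hydrogen, on an aromatic carbon meta to a large group, moves the number by more than the usual scatter, though only modestly. Compound 1, with neither added group, now has the highest number of the three compounds, so each of the two replacements of hydrogen shown here, bromo and cyano, has lowered the number, and no compound shown goes against this. No measurement is available that would explain the size or direction of the cyano step.

The compounds shown leave open whether this place responds to cyano alone or to other groups as well, such as an amine, a carboxylic acid, a methoxy group or a longer chain. They also leave open whether cyano would give a similar step on another carbon of the same ring, as a single compound cannot separate the effect of the group from that of its place.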